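The source may hold more compounds than are shown below. What is called first, only, known or untested is meant among the compounds shown, and "the series" means these compounds.

Compound 1 `CCCNc1cc(NC(=O)c2ccccn2)cc(C(F)(F)F)c1` and compound 2 `CCCN(C)c1cc(NC(=O)c2c(F)cccc2F)cc(C(F)(F)F)c1` share the core of the series. In an assay on HEK293-TREx cells for antagonist activity at transient receptor potential cation channel subfamily A member 1 (Homo sapiens), read by calcium flux (on this read-out higher numbers stand for weaker inhibition and lower numbers for stronger inhibition), compound 1 gives only a limit, > 32000 nM. Compound 2 likewise gives only a limit in this assay, > 32000 nM. Compound 2 therefore stands at the ceiling of the numbers shown, where both values sit (the limit of > 32000 nM in this assay, at which 2 of the 2 values shown sit). Compound 3 `CCCOc1cc(NC(=O)c2c(F)cccc2F)cc(C(F)(F)F)c1` differs from compound 2 by propoxy in place of methyl(propyl)amino on an aromatic carbon. Going by the values given here, no measured step between compounds is available, so no direction is indicated; the expected step, a step that the limit leaves unreadable from compound 2 to compound 3, is none beyond the scatter. Compound 3 is estimated at 40000 nM, within 10000 nM to 150000 nM. Compound 3 is expected most likely to return only a limit as well.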

Compound 3, half-maximal inhibitory concentration: > 32000 nM
Compound 3 was reported as a limit (the forecaster's own chance of this, stated with the estimate: 85%); the middle value lies beyond the limit too.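

Compound 2 and compound 3 both return only limits in this assay, so no step can be read between them. The compounds shown leave open how propoxy and methyl(propyl)amino compare, and whether any compound on this core gives a measurable value.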